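The source may hold more compounds than are shown below. What is called first, only, known or untested is meant among the compounds shown, and "the series" means these compounds.

Compound 1 `CNC(=O)/C=C/c1ccc(NC(=O)Nc2ccc(Cl)c(C(F)(F)F)c2)cc1` is the anchor of this small set; in a functional assay on A-375 cells (Homo sapiens) for inhibition, read by MTT assay, with a stated time of 120 h (a lower number here means a stronger inhibitor, a higher number a weaker inhibitor), compound 1 gives 20900 nM. Compound 2 `CNC(=O)/C(C)=C/c1ccc(NC(=O)Nc2ccc(Cl)c(C(F)(F)F)c2)cc1` differs from it by 2-(methylcarbamoyl)prop-1-en-1-yl in place of 2-(methylcarbamoyl)ethenyl on an aromatic carbon. In this assay compound 2 reaches only a limit, > 50000 nM. Compound 3 `CC1CN(C(=O)/C=C/c2ccc(NC(=O)Nc3ccc(Cl)c(C(F)(F)F)c3)cc2)CC(C)O1` differs from compound 1 by 2,6-dimethylmorpholin-4-yl in place of methylamino on a carbonyl carbon. In this assay compound 3 also stops at a limit, > 50000 nM. Both steps, an at least 2.3-fold higher number from compound 1 to compound 2 (0.37 log units; beyond the scatter) and an at least 2.3-fold higher number from compound 1 to compound 3 (0.37 log units; beyond the scatter), end at the limit of > 50000 nM in this assay, at which 2 of the 3 values shown sit. Compound 4 `C/C(=C\c1ccc(NC(=O)Nc2ccc(Cl)c(C(F)(F)F)c2)cc1)C(=O)N1CC(C)OC(C)C1` has not been measured; it differs from compound 2 by 2,6-dimethylmorpholin-4-yl in place of methylamino on a carbonyl carbon, the same change that separates compound 3 from compound 1, at the same place. Beside that earlier step, the author expects from compound 2 to compound 4 a step that the limit leaves unreadable from compound 2 to compound 4, resting on the fact that compound 2 already stands at > 50000 nM in this assay. The author estimates compound 4 at 90000 nM.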

Compound 4, half-maximal inhibitory concentration: > 50000 nM
Compound 4: no number, only a limit; the forecaster's own chance of this, stated with the estimate: 85%; the middle value does not contradict the limit.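

In this assay compound 4 also stops at a limit, > 50000 nM, so no step from compound 2 to compound 4 can be read: the limit of > 50000 nM in this assay, at which 3 of the 4 values shown sit.

The compounds shown leave open what actual values compound 2, compound 3 and compound 4 have, and so whether 2,6-dimethylmorpholin-4-yl in place of methylamino changes compound 2 as much as it changes compound 1.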